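This account rests on a few compounds, and the source may have more. Where it says the series, first, only, none or still open, it means among the compounds named here.

Measured compounds:
compound 1 `N=C(S)CCCCCCN1N=C(c2ccccc2)CCC1=O`: 58.8 mg/kg
compound 2 `N=C(S)CCn1nc(-c2ccccc2)ccc1=O`: 87.3 mg/kg
compound 3 `N=C(S)CCCCN1N=C(c2ccccc2)CCC1=O`: 100 mg/kg

All three numbers come from a functional assay on the whole organism (stomach) with Rattus norvegicus as the target; on this read-out higher numbers stand for an effect only at larger amounts of compound and lower numbers for an effect already at smaller amounts. Compound 3 and compound 1 differ in one place, (a group of 5 heavy atoms (3 carbon, 1 nitrogen, 1 sulfur; no ring) in place of a group of 3 heavy atoms (1 carbon, 1 nitrogen, 1 sulfur; no ring), on a saturated chain carbon, four bonds along the chain from an amide-type nitrogen in a ring); the step is a 1.7-fold lower number from compound 3 to compound 1 (0.23 log units; within the scatter). Compound 2 carries the same chain as compound 3 on another core; the difference between the two cores is not broken down here. Compound 4 `N=C(S)CCCCn1nc(-c2ccccc2)ccc1=O` is still to be measured. It stands to compound 2 as compound 1 stands to compound 3, through (a group of 5 heavy atoms (3 carbon, 1 nitrogen, 1 sulfur; no ring) in place of a group of 3 heavy atoms (1 carbon, 1 nitrogen, 1 sulfur; no ring), on a saturated chain carbon, two bonds along the chain from an aromatic nitrogen). The place is not the same: in the measured pair the change sits four bonds along the chain from an amide-type nitrogen in a ring, here two bonds along the chain from an aromatic nitrogen, so this is the same kind of change, not the same one. Going by the values given here, only one measured instance exists. Compound 4 is expected to move by about a 1.5-fold lower number from compound 2 to compound 4 (0.16 log units; within the scatter), which rests on the step of a 1.7-fold lower number from compound 3 to compound 1 (0.23 log units; within the scatter) seen from compound 3. The estimate for compound 4 is 60 mg/kg, with a range from 32 mg/kg to 115 mg/kg.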

Compound 4, dose for half-maximal effect: > 100 mg/kg
Compound 4: no number, only a limit (the forecaster's own chance of this, stated with the estimate: 10%); middle value at least 1.6-fold (0.22 log units) from the limit.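

In this assay compound 4 gives > 100 mg/kg, which is a limit of the assay and not a number. The new step is an at least 1.1-fold higher number from compound 2 to compound 4 (0.05 log units; that floor lies within the scatter), and beside the earlier step it neither confirms nor rules out that the change carries from one core to the other: the same change on two cores in this assay, a 1.7-fold lower number (0.23 log units; within the scatter) from compound 3 to compound 1 and an at least 1.1-fold higher number (0.05 log units; that floor lies within the scatter) from compound 2 to compound 4; the limit leaves it open whether they differ. The series therefore holds one measured instance of this change and one bounded by a limit, which gives no rule for transferring it between these cores.

On these data alone, the actual value of compound 4 remains open. Also open, as far as these compounds go, is how a longer chain or a carboxylic acid on the core of compound 2 would read out in this assay.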